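Moving Fluorines on the Amide Aryl Group

This account rests on a few compounds, and the source may have more. Where it says the series, first, only, none or still open, it means among the compounds named here.

Compound 3 `C/C(=N\OCC(=O)Nc1ccc(C(F)(F)F)cc1)C1=C(O)c2ccccc2S(=O)(=O)N1C` carries a 4-(trifluoromethyl)phenyl on its amide-type nitrogen. In a functional assay on THP-1 cells (Homo sapiens) for inhibition, read by ELISA, with stated times of 2 h and 48 h (a higher number here means a weaker inhibitor, a lower number a stronger inhibitor), compound 3 gives only a limit, > 20000 nM. Compound 2 `C/C(=N\OCC(=O)Nc1cccc(F)c1)C1=C(O)c2ccccc2S(=O)(=O)N1C` likewise gives only a limit, > 20000 nM. Compound 1 `CCOC1=C(/C(C)=N/OCC(=O)Nc2c(F)cccc2F)N(C)S(=O)(=O)c2ccccc21`, which differs from the others elsewhere in the shared core, also gives only a limit, > 20000 nM. All three values therefore sit at the limit of > 20000 nM in this assay, at which 3 of the 3 values shown sit, so the step that the two limits leave unreadable from compound 2 to compound 3 cannot be read. Compound 4 `C/C(=N\OCC(=O)Nc1c(F)cccc1F)C1=C(O)c2ccccc2S(=O)(=O)N1C` changes compound 3 by 2,6-difluorophenyl in place of 4-(trifluoromethyl)phenyl on an amide-type nitrogen. Among the measured compounds shown here, no measured step has a readable size, so no direction can be expected beyond the scatter, and compound 4 shares its 2,6-difluorophenyl with compound 1, whose value is a limit. Compound 4 is expected to give 30000 nM, between 8000 nM and 100000 nM. That estimate means a step that the limit leaves unreadable from compound 3 to compound 4.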

Compound 4, half-maximal inhibitory concentration: > 20000 nM
Compound 4 ended at the assay's limit; the forecaster's own chance of this, stated with the estimate: 85%; the middle value does not contradict the limit.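

Among the compounds shown here, compound 4 gives only a limit, > 20000 nM, so no step linking it to compound 1, compound 2 or compound 3 can be read in this assay. The compounds shown leave open whether any of these groups on the amide-type nitrogen changes inhibition: the limit of > 20000 nM in this assay, at which 4 of the 4 values shown sit.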